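Chloro Substitution on a Shared Pyrazolyl Core and Growth Inhibition

The compounds below may be only part of what the source reports. "The series", "measured", "known", "first", "only" and "open" are said of these compounds alone.

Three compounds in this series were tested in a functional assay on Hs-578T cells (Homo sapiens) for inhibition, read by sulforhodamine B assay, with a stated time of 48 h; a higher number here means a weaker inhibitor of growth, a lower number a stronger inhibitor of growth. Compound 1 `N#Cc1c(-c2nnc(-c3nn(-c4ccccc4)c(-c4ccccc4)c3C#N)c3nn(-c4ccccc4)cc23)nn(-c2ccccc2)c1-c1ccccc1` gives 94400 nM in this assay. Compound 2 `N#Cc1c(-c2nnc(-c3nn(-c4ccccc4)c(-c4ccccc4)c3C#N)c3nn(-c4ccc(Cl)cc4)cc23)nn(-c2ccccc2)c1-c1ccccc1` differs from compound 1 in a single place, (chloro in place of hydrogen on an aromatic carbon), and in this assay compound 2 gives 9720 nM. That single change produced a 9.7-fold lower number from compound 1 to compound 2 (0.99 log units; beyond the scatter).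

Compound 3 `N#Cc1c(-c2nnc(-c3ccccc3)c3nn(-c4ccccc4)cc23)nn(-c2ccccc2)c1-c1ccccc1` carries a different core; the difference between the core of compound 1 and the core of compound 3 is not broken down here. In this assay compound 3 gives 31800 nM, a number that sits between those of compound 1 and compound 2.

Compound 4 `N#Cc1c(-c2nnc(-c3ccccc3)c3nn(-c4ccc(Cl)cc4)cc23)nn(-c2ccccc2)c1-c1ccccc1` has not yet been measured. Within the data shown here, it differs from compound 3 by chloro in place of hydrogen on an aromatic carbon, and its place line reads the same, word for word, as the one that separates compound 2 from compound 1: the change is therefore the same change applied on a different core. On this basis the expected step is a 7.1-fold lower number from compound 3 to compound 4 (0.85 log units; beyond the scatter), a step estimated to lie near the one seen earlier, because compound 2 reached 9720 nM from the number of compound 1 by the same change. Among the measured compounds shown here, with only one earlier instance to rest on, the estimate is drawn a little toward the starting point of compound 3. Compound 4 is therefore expected to give about 4500 nM in this assay, most likely between 1500 nM and 15000 nM.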

Compound 4, concentration for 50% growth inhibition: 16800 nM
The estimate for compound 4 lay 3.7-fold (0.57 log units) below the measured number; measured number above the stated range.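

On the other core, in this assay, the same change of phenyl to 4-chlorophenyl gives a 1.9-fold lower number from compound 3 to compound 4 (0.28 log units; within the scatter), a step that cannot be told from the scatter of repeated measurements. Set beside the step on the first core, the result is not the same, and the two steps differ by more than their scatter allows: the same change on two cores in this assay, a 9.7-fold lower number (0.99 log units; beyond the scatter) from compound 1 to compound 2 and a 1.9-fold lower number (0.28 log units; within the scatter) from compound 3 to compound 4, 5.1-fold (0.71 log units) apart, beyond the scatter of two such steps. The clear step seen on the core of compound 1 therefore did not carry over at the same size to the core of compound 3, so in this series the step measured on one core is not a safe guide to the step on the other, but two pairs in a single assay do not show what in the cores sets the difference, nor how the change would behave on any further core.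

The compounds shown carry only hydrogen or chloro at this place on the aromatic ring, so it remains open whether fluoro, bromo, methoxy or an amine there would give steps that also differ between the two cores. From the compounds shown here alone, it also remains open whether the same gap between the two steps would appear in growth inhibition of other cell lines.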